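Bromo to methoxy on the aryl amide series

The source may report more compounds than this note shows. Statements on the series, on what has been measured and on what is new or still open speak of the compounds shown alone.

Two compounds of the shared core carry measurements. Compound 1 `COc1ccc(-n2cc(C(=O)Nc3ccc(Oc4ccnc5c4ccn5C)c(F)c3)c(=O)c3ccccc32)cc1` in a functional assay on MCF7 cells (Homo sapiens) for inhibition, read by MTT assay, with a stated time of 72 h (a higher number here means a weaker inhibitor, a lower number a stronger inhibitor), gives 6720 nM. Compound 2 `O=C(Nc1ccc(Oc2ccnc3[nH]ccc23)c(F)c1)c1cn(-c2ccc(Br)cc2)c2ccccc2c1=O` in this assay gives 650 nM, the lower of the two numbers and the stronger inhibitor, with compound 1 as its nearest neighbour at a markedly higher number; compound 1 and compound 2 differ in more than one place, so the gap between them is not assigned to a single change.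

Compound 3 `COc1ccc(-n2cc(C(=O)Nc3ccc(Oc4ccnc5[nH]ccc45)c(F)c3)c(=O)c3ccccc32)cc1` is the next entry, not yet measured in this assay. It differs from compound 2 in one place: methoxy in place of bromo on an aromatic carbon. Going by the values given here, no measured pair isolates this change. Compound 3 shares the methoxyphenyl group with compound 1, whose value is 6720 nM, and the remainder of its structure with compound 2, whose value is 650 nM.

A moderate step upward from compound 2, beyond the usual scatter, is expected a 2.8-fold higher number from compound 2 to compound 3 (0.44 log units; beyond the scatter), landing between the two measured numbers. Compound 3 is estimated at 1800 nM in this assay, with a range from 600 nM to 5500 nM.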

Compound 3, half-maximal inhibitory concentration: 6620 nM
Compound 3: the middle estimate sits 3.7-fold (0.57 log units) below what was measured; the measured number lies above the stated range.
By their numbers in this assay, from the lowest: compound 2; then compounds 3 and 1 (each within the scatter of the next).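

Moving from 4-bromophenyl to 4-methoxyphenyl gives the first single-change reading at this position: in this assay it produces a 10-fold higher number from compound 2 to compound 3 (1.01 log units; beyond the scatter), a large step. Hydrogen in place of methyl on an aromatic nitrogen gives a 1.0-fold lower number from compound 1 to compound 3 (0.01 log units; within the scatter), within the scatter, so with 4-methoxyphenyl in place this nitrogen substituent makes no readable difference, and the gap left unassigned between compound 1 and compound 2 is matched by the step at the aryl position. No evidence is at hand to explain either step.

From the compounds shown here alone, only bromo and methoxy have been read at this position, so how hydrogen, chloro, an amine or a carboxylic acid there would compare remains open. Going by these compounds alone, it also remains open whether methyl on the aromatic nitrogen would be equally silent with 4-bromophenyl in place, since the single step for that change carries 4-methoxyphenyl.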